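The source may hold more compounds than are shown below. What is called first, only, known or untested is meant among the compounds shown, and "the series" means these compounds.

The shared core of these compounds carries a hydrazide side chain, and the three measured members differ only in what sits on its outer nitrogen. Compound 1 `NNC(=O)c1c(NC(=O)NS(=O)(=O)c2ccccc2)sc2c1CCCCC2` leaves that nitrogen bare, and in a functional assay on UACC-257 cells (Homo sapiens) for inhibition, with a stated time of 48 h (on this read-out lower numbers stand for stronger inhibition of growth and higher numbers for weaker inhibition of growth), compound 1 gives 2800 nM. Compound 2 `O=C(Nc1sc2c(c1C(=O)NNc1ccccc1)CCCCC2)NS(=O)(=O)c1ccccc1` carries a phenyl there. In this assay compound 2 reaches only a limit of the assay, > 100000 nM. Compound 3 `O=C(Nc1sc2c(c1C(=O)NNc1ccc(Br)cc1)CCCCC2)NS(=O)(=O)c1ccccc1` carries a 4-bromophenyl instead. In this assay compound 3 likewise sits at a limit, > 100000 nM. Compound 3 therefore stands at the weak end of what has been measured, sharing the limit of > 100000 nM in this assay, at which 2 of the 3 values shown sit, with compound 2, far from compound 1. The steps of an at least 35-fold higher number from compound 1 to compound 2 (1.55 log units; beyond the scatter) and an at least 35-fold higher number from compound 1 to compound 3 (1.55 log units; beyond the scatter) both show that putting an aryl group on that nitrogen costs a great deal, while the step that the two limits leave unreadable from compound 2 to compound 3 cannot be read, both of its numbers being limits.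

Compound 4 `O=C(Nc1sc2c(c1C(=O)NNc1ccc(Cl)cc1)CCCCC2)NS(=O)(=O)c1ccccc1` differs from compound 3 by chloro in place of bromo on an aromatic carbon. Among the measured compounds shown here, no measured pair with numbers at both ends covers a halogen swap on this ring, and both aryl-bearing compounds sit at the limit, so the step of a number no higher from compound 3 to compound 4 (the limit leaves the size open) is expected to be none beyond the scatter. Compound 4 is expected to give 100000 nM in this assay, with a range from 30000 nM to 300000 nM, most likely again reported only as a limit.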

Compound 4, concentration for 50% growth inhibition: > 100000 nM
Compound 4 was reported as a limit; the forecaster's own chance of this, stated with the estimate: 80%; the middle value sits exactly at the limit.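

With 4-chlorophenyl on the outer nitrogen of the hydrazide, a third aryl group joins phenyl and 4-bromophenyl in the same heavy loss, seen in this assay as an at least 35-fold higher number from compound 1 to compound 4 (1.55 log units; beyond the scatter). The loss therefore does not depend on the bromo group, since a chloro on the same place, para to a large group, leaves the compound at the limit too, but this says nothing about how the two halogens rank, and the steps among compound 2, compound 3 and compound 4 cannot be read because all of their numbers are limits. Among the compounds shown, only compound 1, with its bare nitrogen, gives a real number, while the aryl-bearing compounds gather at one end of the scale: the limit of > 100000 nM in this assay, at which 3 of the 4 values shown sit.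

Going by these compounds, how weak the three aryl-bearing compounds truly are remains open, as the limit hides any differences among them. Also open, on these data alone, is whether a methyl or an ethyl on that nitrogen, in place of an aryl ring, would keep growth inhibition close to that of compound 1, which would show whether any added group is costly or only an aryl ring.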